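The source may report more compounds than this note shows. Statements on the series, on what has been measured and on what is new or still open speak of the compounds shown alone.

In an ADME assay on L6 cells (Rattus norvegicus) for cytotoxicity, read by resazurin assay, with a stated time of 70 h (a lower number here means a stronger inhibitor, a higher number a weaker inhibitor), compound 1 `Cc1ccccc1C(=O)Nc1cc(Cl)ccn1` gives 224000 nM while compound 2 `Cc1ccc(C(=O)Nc2ccccn2)c(C)c1` gives 283000 nM and compound 3 `Cc1cc(Br)ccc1C(=O)Nc1ccccn1` gives 193000 nM and these three values lie within the usual scatter of one another, so compound 1 holds no distinct rank among them. Compound 4 `Cc1ccccc1C(=O)Nc1cc(-c2ccccc2)ccn1` carries phenyl in place of chloro on an aromatic carbon and this change has not yet been tested. For the measured compounds named here, the one measured single-place swap, bromo in place of methyl, is a 1.5-fold lower number from compound 2 to compound 3 (0.17 log units; within the scatter) and it sits at a different place, so it is only a weak guide. Since a whole ring enters here, a moderately lower number is expected, an estimated 2.8-fold lower number from compound 1 to compound 4 (0.45 log units; beyond the scatter) in this assay. For compound 4 the expected value is 80000 nM with an estimated range from 25000 nM to 220000 nM.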

Compound 4, half-maximal inhibitory concentration: 70000 nM
For compound 4 the middle estimate is 1.1-fold (0.06 log units) above the measured one; the measured number falls inside the stated range.
By their numbers in this assay, from the lowest: compound 4; then compounds 3, 1 and 2 (each within the scatter of the next).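

In this assay, phenyl in place of chloro, on the aromatic carbon opposite the ring nitrogen, gives a 3.2-fold lower number from compound 1 to compound 4 (0.51 log units; beyond the scatter). Unlike the one earlier step, this change lies beyond the scatter, so this position can take a whole ring, six heavy atoms where one left, and the number still falls. Nothing measured here explains that fall.

From the compounds shown here alone, whether it takes a ring specifically remains open. An amine, a carboxylic acid or a longer chain on the same carbon could move the number either way.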